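Sulfur substituent swap on compound 2

A few compounds are considered here, and "the series" means these few. Any claim that something is new, unique, unknown or untested is made for them only; others in the source may bear on it.

In a functional assay on DU-145 cells (Homo sapiens) for inhibition, read by trypan blue exclusion, with a stated time of 96 h (a higher number here means a weaker inhibitor of growth, a lower number a stronger inhibitor of growth), compound 1 (`O=C(/C(=C\c1ccc(O)cc1O)SCc1ccc(Cl)cc1)c1ccc(Cl)cc1`) gives 50000 nM and compound 3 (`Cc1ccc(/C=C(/SCc2ccc(Cl)cc2)C(=O)c2ccc(Cl)cc2)s1`) gives 50000 nM while compound 2 (`O=C(/C(=C\c1ccc(Br)cc1)SCc1ccc(Cl)cc1)c1ccc(Cl)cc1`) gives 1000 nM as the lowest of the three numbers. Compared with compound 2, compound 4 (`O=C(/C(=C\c1ccc(Br)cc1)Sc1ccc(Br)cc1)c1ccc(Cl)cc1`) has 4-bromophenyl in place of 4-chlorobenzyl on a sulfur. Every measured step changes the group on the double-bonded chain carbon instead, with a 50-fold lower number from compound 1 to compound 2 (1.70 log units; beyond the scatter) and a 50-fold higher number from compound 2 to compound 3 (1.70 log units; beyond the scatter) as large moves and no change at the digits printed from compound 1 to compound 3 (within the scatter) inside the scatter of repeats. None of these tests the sulfur substituent, so the data fix no direction. A moderate rise is expected, with a 3.0-fold higher number from compound 2 to compound 4 (0.48 log units; beyond the scatter) as the estimated step and wide uncertainty. In this assay the estimated value for compound 4 is 3000 nM (expected range 700 nM to 20000 nM).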

Compound 4, concentration for 50% growth inhibition: 1000 nM
Estimate against measurement, compound 4: 3.0-fold (0.48 log units) above; the range from low to high includes it.
By their numbers in this assay, from the lowest: compounds 2 and 4 (each within the scatter of the next); then compounds 1 and 3 (each within the scatter of the next).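

In this assay, among these compounds, the first step at this sulfur gives no change at the digits printed from compound 2 to compound 4 (within the scatter), so 4-bromophenyl and 4-chlorobenzyl cannot be told apart here. This position therefore gives a flat reading for this pair, whereas two of the three steps on the double-bonded chain carbon are large. No supporting evidence bears on this result.

This step swaps the chlorine for bromine and removes the benzyl carbon together, leaving their separate contributions unresolved, and they may offset each other. On these data alone, how an amine or a carboxylic acid on the sulfur substituent would read remains open.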